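Methyl on the nitrogen of compound 1

This account rests on a few compounds, and the source may have more. Where it says the series, first, only, none or still open, it means among the compounds named here.

In a functional assay on MCF7 cells (Homo sapiens) for antiproliferative activity, read by MTT assay, with a stated time of 72 h (a lower number here means a stronger inhibitor, a higher number a weaker inhibitor), compound 1 (`CNc1nc(-c2cc(OC)c(OC)c(OC)c2)c(-c2ccc3ccccc3c2)s1`) gives 21.1 nM as its half-maximal inhibitory concentration. Two close relatives carry other aryl groups on the same core: compound 2 (`CNc1nc(-c2cc(OC)c(OC)c(OC)c2)c(-c2ccc(C)cc2)s1`) at 10.1 nM and compound 3 (`CNc1nc(-c2cc(OC)c(OC)c(OC)c2)c(-c2ccc(OC)cc2)s1`) at 37.6 nM on the same read-out. The number of compound 1 is higher than that of compound 2, by a margin just beyond the scatter, and lies within the scatter of that of compound 3.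

The change to compound 4 (`COc1cc(-c2nc(N(C)C)sc2-c2ccc3ccccc3c2)cc(OC)c1OC`), methyl in place of hydrogen on a nitrogen on an aromatic ring, turns methylamino into dimethylamino (methyl in place of hydrogen on a nitrogen on an aromatic ring). Within the data shown here, the only measured single-place step (a 3.7-fold higher number from compound 2 to compound 3 (0.57 log units; beyond the scatter)) puts methoxy in place of methyl on an aromatic carbon, not on this nitrogen. That step is modest and beyond the scatter, but it bears on the new change only as a rough guide to size. Among the measured compounds shown here, no measured pair varies the group on this nitrogen, so the direction rests on the structural change alone and remains uncertain. In this assay a modest move toward a higher number is expected (a 3.3-fold higher number from compound 1 to compound 4 (0.52 log units; beyond the scatter)) as the estimated step. For compound 4 the estimated value is 70 nM with an expected range from 18 nM to 300 nM in this series.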

Compound 4, half-maximal inhibitory concentration: 2390 nM
Estimate against measurement, compound 4: 34-fold (1.53 log units) below, and the stated range ends below it.
By their numbers in this assay, from the lowest: compound 2; then compounds 1 and 3 (each within the scatter of the next); then compound 4.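

In this assay, this nitrogen responds sharply to a small change: a single methyl, turning methylamino into dimethylamino, gives a 110-fold higher number from compound 1 to compound 4 (2.05 log units; beyond the scatter). Among these compounds, that step is far larger than the only earlier single-place step, a 3.7-fold higher number from compound 2 to compound 3 (0.57 log units; beyond the scatter), which concerned an aromatic carbon rather than this nitrogen. Among the compounds shown here, compound 1 at 21.1 nM therefore marks methylamino as much the better of the two groups tested here on the core of compound 1, while compound 4 at 2390 nM gives the first reading of dimethylamino, and nothing at hand accounts for the size of this step.

A free amino group, ethylamino or an acetamide on the same nitrogen would help separate the effect of losing the hydrogen on this nitrogen from the effect of the added carbon, and the compounds shown do not settle that question. As far as these compounds go, it also remains open whether dimethylamino carries a similar penalty when paired with the aryl group of compound 2 or compound 3.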